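Adding Chlorine to Compound 2: What to Expect

The source may hold more compounds than are shown below. What is called first, only, known or untested is meant among the compounds shown, and "the series" means these compounds.

Compound 1 `CS(=O)(=O)c1ccc(C2=NN(c3ccc(C(=O)O)cc3)C(c3ccccc3)C2)cc1` and compound 2 `CS(=O)(=O)c1ccc(C2=NN(c3ccc(S(N)(=O)=O)cc3)C(c3ccccc3)C2)cc1` share one core and were tested in a functional assay on the whole organism for inhibition, with Rattus norvegicus as the target, read by paw edema, with a stated time of 3 h, at a dose of 50 mg/kg by the oral route; a lower number here means less inhibition, a higher number more inhibition at the dose given (going by the name of the read-out). Compound 1 gives 56.4%, and compound 2 gives 54.3%; the step of a number 2.1 percentage points lower from compound 1 to compound 2 (within the scatter) leaves the two within the scatter, so compound 2 stands level with compound 1. Compound 3 `CS(=O)(=O)c1ccc(C2=NN(c3ccc(S(N)(=O)=O)cc3)C(c3ccc(Cl)cc3)C2)cc1` differs from compound 2 by chloro in place of hydrogen on an aromatic carbon. Going by the values given here, no measured step involves a chloro for a hydrogen; the only measured step concerns a sulfamoyl in place of a carboxy elsewhere, so it gives no guide. A step within the scatter is expected, a number 0.7 percentage points higher from compound 2 to compound 3 (within the scatter). Compound 3 is therefore estimated at 55%, with a range from 40% to 70%.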

Compound 3, a percentage reported as inhibition, in the whole organism at one dose (the size of the read-out at that dose, not a potency): 42.4%
For compound 3 the middle estimate is 12.6 percentage points above the measured one, and the stated range covers the measured number.
By their numbers in this assay, from the lowest: compound 3; then compounds 2 and 1 (each within the scatter of the next).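

In this assay the change from phenyl to 4-chlorophenyl gives a number 11.9 percentage points lower from compound 2 to compound 3 (beyond the scatter) with just one added heavy atom. The earlier step, sulfamoyl in place of carboxy, stayed within the scatter, so this is the first change shown that clearly moves the number. Nothing shown here explains the fall.

As far as these compounds go, whether fluoro, methyl or methoxy at this place would also lower the number stays open. So does whether chloro would have the same effect on compound 1, which carries carboxy instead of sulfamoyl.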